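This account rests on a few compounds, and the source may have more. Where it says the series, first, only, none or still open, it means among the compounds named here.

Measured so far:
- compound 1 `N#C/C(=C\c1ccccc1OS(=O)(=O)c1ccccc1[N+](=O)[O-])C(=O)Nc1nnc(Cc2cccc3ccccc23)s1`: 23%
- compound 2 `N#C/C(=C\c1ccccc1OS(=O)(=O)c1ccccc1[N+](=O)[O-])C(=O)Nc1nnc(Cc2ccccc2)s1`: 12%
- compound 3 `COc1ccc(S(=O)(=O)Oc2ccccc2/C=C(\C#N)C(=O)Nc2nnc(Cc3cccc(F)c3)s2)cc1`: 100%

In a functional assay on HL-60 cells (Homo sapiens) for inhibition, read by CCK-8 assay, with a stated time of 48 h, tested at 20 uM (on this read-out higher numbers stand for more inhibition of growth at the one concentration tested and lower numbers for less inhibition of growth), compound 3 stands highest of the three at 100%, and its distance to each of the others lies well beyond the scatter. Compound 4 `N#C/C(=C\c1ccccc1OS(=O)(=O)c1ccccc1[N+](=O)[O-])C(=O)Nc1nnc(Cc2cccc(F)c2)s1` keeps everything in compound 3 except one group, with 2-nitrophenyl in place of 4-methoxyphenyl on a sulfonyl sulfur.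

Going by the values given here, no measured step makes this exchange. Among the compounds with values here, the only step available, a number 11 percentage points lower from compound 1 to compound 2 (beyond the scatter), is modest and lies at the other end of the molecule, on a saturated chain carbon bound to an aromatic carbon. It suggests that a change at that end can move the number, but says nothing directly about the sulfonyl side.

The closer guide is that compound 1 and compound 2 both carry the 2-nitrophenyl group that enters compound 4. Compound 1 gives 23%, and compound 2 gives 12%. Within the data shown here, no measured compound separates the contributions of the two ends, so some uncertainty remains, and a large fall is expected rather than a certain one.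

The estimate means an expected a number 72 percentage points lower from compound 3 to compound 4 (beyond the scatter). Compound 4 is expected at 28%, with an estimated range from 8% to 70%.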

Compound 4, percent growth inhibition at one concentration: 23%
Estimate against measurement, compound 4: 5 percentage points above; the range from low to high includes it.
By their numbers in this assay, from the lowest: compound 2; then compounds 1 and 4 (each within the scatter of the next); then compound 3.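

With the 3-fluorophenyl group held fixed, the exchange on the sulfonyl sulfur can now be read directly: in this assay there is a number 77 percentage points lower from compound 3 to compound 4 (beyond the scatter) for 2-nitrophenyl in place of 4-methoxyphenyl, a large step. With 2-nitrophenyl kept on the sulfonyl sulfur, the other end of the molecule moves the number far less: there is a number 11 percentage points higher from compound 2 to compound 4 (beyond the scatter) for fluoro in place of hydrogen on an aromatic carbon, and no change at the digits printed from compound 1 to compound 4 (within the scatter) when naphthalen-1-yl gives way to 3-fluorophenyl at that end. Among these compounds the sulfonyl substituent is therefore the change that goes with the large move, while the three compounds carrying 2-nitrophenyl all stay at the low end of the read-out.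

From the compounds shown here alone, this exchange is seen in a single pair, so it remains open whether it would have the same size with phenyl or naphthalen-1-yl at the other end, and whether a 4-aminophenyl or 4-methylphenyl group on the sulfonyl sulfur would fall nearer compound 3 or compound 4. Nothing available here accounts for the size of the fall from the 4-methoxyphenyl compound.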